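The source may report more compounds than this note shows. Statements on the series, on what has been measured and on what is new or still open speak of the compounds shown alone.

Measured in a functional assay on L02 cells (Homo sapiens) for inhibition; a higher number here means a weaker inhibitor, a lower number a stronger inhibitor:
- compound 1 `CCN(CC)CCNC(=O)CC(CC(=O)NC1Cc2ccccc2C1)c1ccc(Cl)cc1`: 76700 nM
- compound 2 `CCN(C(=O)CC(CC(=O)NCCN1CCCC1)c1ccc(Cl)cc1)C1Cc2ccccc2C1`: 54200 nM

Compound 2 stands level with compound 1 in this assay. The gap between their numbers lies within the usual scatter of repeated measurements, so neither can be called the stronger inhibitor.

The next compound, compound 3 `CCN(CC)CCNC(=O)CC(CC(=O)N(CC)C1Cc2ccccc2C1)c1ccc(Cl)cc1`, differs from compound 2 in one place: diethylamino in place of pyrrolidin-1-yl on a saturated chain carbon, two bonds along the chain from an amide-type nitrogen. Put simply, diethylamino takes the place of pyrrolidin-1-yl on a saturated chain carbon, two bonds along the chain from an amide-type nitrogen. The group that leaves holds a ring and the group that enters holds none.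

Among the compounds with values here, no pair of measured compounds shows this swap on its own, so the data give no direct size for it. Within the data shown here, the only guide is that the two measured numbers sit within the scatter of each other. The expectation is therefore no step beyond the scatter in this assay, and no firm direction. The estimated change is a 1.1-fold higher number from compound 2 to compound 3 (0.03 log units; within the scatter). Compound 3 is expected at 58000 nM, with an estimated range of 27000 nM to 120000 nM.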

Compound 3, half-maximal inhibitory concentration: 78400 nM
For compound 3 the middle estimate is 1.4-fold (0.13 log units) below the measured one, and the stated range covers the measured number.
By their numbers in this assay, from the lowest: compounds 2, 1 and 3 (each within the scatter of the next).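

In this assay the swap of pyrrolidin-1-yl for diethylamino, on a saturated chain carbon, two bonds along the chain from an amide-type nitrogen, now has a measured size (a 1.4-fold higher number from compound 2 to compound 3 (0.16 log units; within the scatter)), so at this place a group with a ring and a group without one, each with the same count of heavy atoms, cannot be told apart. Compound 3 also gives a reading of a second change, ethyl in place of hydrogen on an amide-type nitrogen (a 1.0-fold higher number from compound 1 to compound 3 (0.01 log units; within the scatter)), and this step too stays inside the normal spread of repeat measurements. All three compounds therefore stand level, and neither the ring nor the added ethyl can be linked to stronger or weaker inhibition in these cells.

Still open, from the compounds shown here alone, is whether a different group at the chain end, such as morpholin-4-yl, a primary amine or a carboxylic acid, or a longer chain leading to it, would shift the number beyond that spread. No supporting measurement bears on this result, so the flat outcome stays unexplained.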